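A few compounds are considered here, and "the series" means these few. Any claim that something is new, unique, unknown or untested is made for them only; others in the source may bear on it.

Three compounds on a shared core were tested in a functional assay on CEM-DNR-bulk cells (Homo sapiens), read by MTT assay, with a stated time of 72 h (a higher number here means a weaker inhibitor, a lower number a stronger inhibitor), and none gave an actual number. Compound 1 `Nc1nc2c(c(-c3ccco3)cn2[C@@H]2O[C@H](CO)[C@@H](O)[C@H]2O)c(=O)[nH]1` gives > 20000 nM as a limit and not a number. Compound 2 `Nc1nc2c(c(-c3cccs3)cn2[C@@H]2O[C@H](CO)[C@@H](O)[C@H]2O)c(=O)[nH]1` gives > 20000 nM as a limit too. Compound 3 `Nc1nc2c(c(-c3ccsc3)cn2[C@@H]2O[C@H](CO)[C@@H](O)[C@H]2O)c(=O)[nH]1` likewise stands only at the limit of > 20000 nM in this test. The evidence is therefore the limit of > 20000 nM in this assay, at which 3 of the 3 values shown sit, and no more. Compound 4 `Nc1nc2c(c(-c3cc4ccccc4o3)cn2[C@@H]2O[C@H](CO)[C@@H](O)[C@H]2O)c(=O)[nH]1` takes 1-benzofuran-2-yl in place of thiophen-3-yl on an aromatic carbon. The steps a step that the two limits leave unreadable from compound 1 to compound 2 and a step that the two limits leave unreadable from compound 1 to compound 3 and a step that the two limits leave unreadable from compound 2 to compound 3 bear on this swap but have no readable size. The expected step is a number no higher from compound 3 to compound 4 (the limit leaves the size open) and no firm direction is expected. In this assay compound 4 is estimated at 20000 nM within a range of 6000 nM to 40000 nM and may again return only a limit.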

Compound 4, half-maximal inhibitory concentration: > 20000 nM
Compound 4 was reported as a limit (the forecaster's own chance of this, stated with the estimate: 75%); the middle value lies on the limit itself.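

In this assay compound 4 gives > 20000 nM, a limit and not a number, so its steps from compound 1, compound 2 and compound 3 cannot be read. The compounds shown leave open whether these groups on the shared core differ at all in strength.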